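Working notes: nitro for methyl on the sulfonyl aryl

The source may report more compounds than this note shows. Statements on the series, on what has been measured and on what is new or still open speak of the compounds shown alone.

Measured compounds, with their values in a functional assay on SMMC-7721 cells (Homo sapiens) for cytotoxicity, read by MTT assay, with a stated time of 24 h; on this read-out higher numbers stand for weaker inhibition and lower numbers for stronger inhibition:
compound 1, `Cc1ccc(S(=O)(=O)N2C/C(=C\c3cccnc3)C(=O)/C(=C/c3ccccc3C(F)(F)F)C2)cc1`, gives 6700 nM
compound 2, `O=C1/C(=C/c2cccnc2)CN(S(=O)(=O)c2ccc([N+](=O)[O-])cc2)C/C1=C\c1ccccc1C(F)(F)F`, gives 15900 nM
compound 3, `Cc1ccc(S(=O)(=O)N2C/C(=C\c3ccncc3)C(=O)/C(=C/c3ccccc3C(F)(F)F)C2)cc1`, gives 5590 nM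

Compounds 1 and 3 share everything except the difference (pyridin-4-yl in place of pyridin-3-yl on a double-bonded chain carbon bound to a double-bonded ring carbon), and that change is small: a 1.2-fold lower number from compound 1 to compound 3 (0.08 log units; within the scatter). Compounds 1 and 2 differ by nitro in place of methyl on an aromatic carbon, and here the step is larger: a 2.4-fold higher number from compound 1 to compound 2 (0.38 log units; beyond the scatter). Compound 3 and compound 2 are not paired by a single change, but their values stand furthest apart among the three.

Compound 4, `O=C1/C(=C/c2ccncc2)CN(S(=O)(=O)c2ccc([N+](=O)[O-])cc2)C/C1=C\c1ccccc1C(F)(F)F`, has not yet been measured in this assay. It differs from compound 3 by nitro in place of methyl on an aromatic carbon. Going by the values given here, this is the same change as the one made from compound 1 to compound 2, at the same place, on the other core. Among the compounds with values here, the only guide to its size is the one step already seen, a 2.4-fold higher number from compound 1 to compound 2 (0.38 log units; beyond the scatter), and the core difference between compound 1 and compound 3 barely moved the value. The expectation is therefore that compound 3 to compound 4 repeats that earlier step, roughly a 2.4-fold higher number from compound 3 to compound 4 (0.38 log units; beyond the scatter). On this basis compound 4 is estimated at 13400 nM, with a likely range from 7000 nM to 26000 nM. A single precedent is a thin basis, so the range is kept wide.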

Compound 4, half-maximal inhibitory concentration: > 20000 nM
Compound 4: a limit, no number; the forecaster's own chance of this, stated with the estimate: 5%; at least 1.4-fold (0.17 log units) between middle value and limit.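

In this assay compound 4 gives > 20000 nM, which is a limit of the assay and not a number. Nitro in place of methyl on the sulfonyl aryl moves the number the same way on both cores, and the second instance reads as an at least 3.5-fold higher number from compound 3 to compound 4 (0.55 log units; beyond the scatter), so the direction carries over in these two pairs while the size of the change on the second core stays unsettled: the same change on two cores in this assay, a 2.4-fold higher number (0.38 log units; beyond the scatter) from compound 1 to compound 2 and an at least 3.5-fold higher number (0.55 log units; beyond the scatter) from compound 3 to compound 4; the limit leaves it open whether they differ. Read the other way round, pyridin-4-yl in place of pyridin-3-yl gives an at least 1.2-fold higher number from compound 2 to compound 4 (0.09 log units; that floor lies within the scatter), so these pairs show no sign that the two pyridine isomers separate, yet they also do not show that the isomers behave alike once nitro is present: the same change on two cores in this assay, a 1.2-fold lower number (0.08 log units; within the scatter) from compound 1 to compound 3 and an at least 1.2-fold higher number (0.09 log units; that floor lies within the scatter) from compound 2 to compound 4; the limit leaves it open whether they differ.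

The compounds shown leave open how far the number for compound 4 lies past the limit, and with it whether nitro for methyl has a larger step on one core than on the other. They also leave open what an amine or a carboxylic acid would give in place of methyl or nitro on the same aromatic carbon, and whether the direction seen in these two pairs would hold for such groups.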